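The source may report more compounds than this note shows. Statements on the series, on what has been measured and on what is new or still open speak of the compounds shown alone.

Compound 1 `O=C1CCC(=O)N1C[C@H]1CN(c2ccc(-n3cc(-c4ccccn4)cn3)c(F)c2)C(=O)O1`: > 400 ug/mL
Compound 2 `O=C1O[C@@H](CSc2cccs2)CN1c1ccc(-n2cc(-c3ccccn3)cn2)c(F)c1`: > 400 ug/mL

Both numbers come from an ADME assay on HEK293-A cells (Homo sapiens) for cytotoxicity, read by MTT assay, with a stated time of 48 h; a lower number here means a stronger inhibitor, a higher number a weaker inhibitor. Compound 1 reaches only the limit of this assay, > 400 ug/mL. Compound 2 likewise gives only the limit, > 400 ug/mL. Compound 2 thus stands at the top of what the assay can report, and its single neighbour sits there as well; the one step shown, a step that the two limits leave unreadable from compound 1 to compound 2, cannot be read in size since both of its compounds sit at the limit of > 400 ug/mL in this assay, at which 2 of the 2 values shown sit. Compound 3 `O=C(NC[C@H]1CN(c2ccc(-n3cc(-c4ccccn4)cn3)c(F)c2)C(=O)O1)C(F)F` has not yet been measured in this assay. It differs from compound 2 by ((difluoromethyl)carbonyl)amino in place of (thiophen-2-yl)sulfanyl on a saturated chain carbon bound to a saturated ring carbon. Within the data shown here, the only measured step that bears on it consists of two limits, so neither a direction nor a size beyond the scatter can be drawn from it. For compound 3 the expected step is a number no higher from compound 2 to compound 3 (the limit leaves the size open), which is taken to leave it near the limit. Compound 3 is therefore estimated at 400 ug/mL, with a range from 200 ug/mL to 800 ug/mL.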

Compound 3, half-maximal inhibitory concentration: 167 ug/mL
Compound 3: the middle estimate sits 2.4-fold (0.38 log units) above what was measured; the whole stated range lies above it.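

In this assay, ((difluoromethyl)carbonyl)amino on a saturated chain carbon bound to a saturated ring carbon gives an at least 2.3-fold lower number from compound 2 to compound 3 (0.37 log units; beyond the scatter), and the same group gives an at least 2.3-fold lower number from compound 1 to compound 3 (0.37 log units; beyond the scatter). Both sizes are minimums, but they show that the group held at this place can move the read-out, and that the two departing groups, for all their differences, are not the only outcome here. The earlier pair could show none of this: the limit of > 400 ug/mL in this assay, at which 2 of the 3 values shown sit.

As far as these compounds go, whether the change belongs to the fluorine atoms, the carbonyl or the amide hydrogen of the entering group remains open. From the compounds shown here alone, what an acetylamino group or a free amine would give at this place is equally open, and so is the true size of both steps.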